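From Carbamate to Benzamide on a Shared Core

This account rests on a few compounds, and the source may have more. Where it says the series, first, only, none or still open, it means among the compounds named here.

Compound 1 `CCOC(=O)N1CCCc2cc(S(=O)(=O)N3CC(c4ccccc4)NC3=O)ccc21` shows the lowest number of the three measured compounds in a functional assay on COLO 205 cells (Homo sapiens) for antiproliferative activity, read by MTT assay (on this read-out higher numbers stand for weaker inhibition and lower numbers for stronger inhibition), giving 2780 nM. Compound 2 `CC(C)COC(=O)N1CCCc2cc(S(=O)(=O)N3CC(c4ccccc4)NC3=O)ccc21` gives 3720 nM, and compound 3 `C=CCOC(=O)N1CCCc2cc(S(=O)(=O)N3CC(c4ccccc4)NC3=O)ccc21` gives 6590 nM. The step of a 1.3-fold higher number from compound 1 to compound 2 (0.13 log units; within the scatter) and the step of a 1.8-fold higher number from compound 2 to compound 3 (0.25 log units; within the scatter) both stay within the scatter, while the step of a 2.4-fold higher number from compound 1 to compound 3 (0.37 log units; beyond the scatter) is modest. The unmeasured compound 4 `O=C(c1ccccc1)N1CCCc2cc(S(=O)(=O)N3CC(c4ccccc4)NC3=O)ccc21` differs from compound 1 by phenyl in place of ethoxy on a carbonyl carbon. Going by the values given here, none of the measured steps replaces ethoxy by phenyl; they only vary the group on the saturated chain carbon bound to the oxygen, and those changes moved the numbers little. The analyst therefore expects only a small shift in this assay, toward a higher number if any, amounting to a 1.4-fold higher number from compound 1 to compound 4 (0.16 log units; within the scatter). For compound 4 the estimate is 4000 nM, between 1500 nM and 12000 nM.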

Compound 4, half-maximal inhibitory concentration: 19300 nM
The estimate for compound 4 lay 4.8-fold (0.68 log units) below the measured number, outside the stated range (above it).
By their numbers in this assay, from the lowest: compounds 1, 2 and 3 (each within the scatter of the next, the first and the last beyond it); then compound 4.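

In this assay, the group on the carbonyl carbon matters more than the earlier changes further out on the chain suggested: phenyl gives a 6.9-fold higher number from compound 1 to compound 4 (0.84 log units; beyond the scatter), a 5.2-fold higher number from compound 2 to compound 4 (0.72 log units; beyond the scatter) and a 2.9-fold higher number from compound 3 to compound 4 (0.47 log units; beyond the scatter). All three steps lie beyond the scatter and point toward a higher number, whichever of ethoxy, isobutoxy or allyloxy leaves. Nothing available explains this shift. The compounds shown leave open whether the higher number follows from losing the chain bound through oxygen or from gaining the aromatic ring. Benzyloxy, methyl or an amine on the same carbonyl carbon would help separate these two readings.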